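Propoxy to isobutoxy on the shared core

This account rests on a few compounds, and the source may have more. Where it says the series, first, only, none or still open, it means among the compounds named here.

Within the data shown here, the series so far holds compound 1 `CCOc1cc(-c2ccccc2)nc2ccccc12` and compound 2 `CCCOc1cc(-c2ccccc2)nc2ccccc12` on a shared core, with compound 3 `CC(C)COc1cc(-c2ccccc2)nc2ccccc12` still to be measured. In a functional assay on HCT-8 cells (Homo sapiens) for cytotoxicity (on this read-out higher numbers stand for an effect only at larger amounts of compound and lower numbers for an effect already at smaller amounts), compound 1 gives > 10 ug/mL as a limit of the assay. In this assay compound 2 gives > 10 ug/mL as a limit too, so its standing is known only as a limit and not as a number.

The change to compound 3 is methyl in place of hydrogen on a saturated chain carbon bound to two saturated chain carbons and reads propoxy to isobutoxy. Among the measured compounds shown here, the one measured step that bears on it also places methyl in place of hydrogen on a saturated chain carbon. That step is a step that the two limits leave unreadable from compound 1 to compound 2 and it offers no size to carry over. The evidence amounts to the limit of > 10 ug/mL in this assay, at which 2 of the 2 values shown sit, and no direction follows from it.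

No step beyond the usual scatter is therefore expected in this assay and another limit is the most likely result. The expected step is a step that the limit leaves unreadable from compound 2 to compound 3 and this remains an estimate. For compound 3 the estimated value is 15 ug/mL with an expected range from 5 ug/mL to 40 ug/mL as the working figure.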

Compound 3, half-maximal effective concentration: > 10 ug/mL
Compound 3: no number, only a limit (the forecaster's own chance of this, stated with the estimate: 75%); the middle value lies beyond the limit too.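

In this assay no new step can be read among compound 1, compound 2 and compound 3, since each stands only as a limit of the assay: the limit of > 10 ug/mL in this assay, at which 3 of the 3 values shown sit.

The compounds shown leave open how far the values of these three compounds lie from that limit, and whether the change from propoxy to isobutoxy shifts the read-out at all.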